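Tetrazole for thiadiazole: from compound 1 to compound 4

The source may hold more compounds than are shown below. What is called first, only, known or untested is meant among the compounds shown, and "the series" means these compounds.

Compound 1 `Cc1nnc(Sc2cc(NC(=O)c3ccc(Cl)cc3)c3ccccc3c2O)s1` carries a (5-methyl-1,3,4-thiadiazol-2-yl)sulfanyl group on the shared core. In a functional assay on MDA-MB-231 cells (Homo sapiens) for antiproliferative activity, read by MTT assay, with a stated time of 48 h (a higher number here means a weaker inhibitor, a lower number a stronger inhibitor), compound 1 gives > 100000 nM, which is a limit of the assay and not a number. Compound 2 `O=C(Nc1cc(Sc2ncn[nH]2)c(O)c2ccccc12)c1cccc(Cl)c1` gives > 100000 nM in this assay, again only a limit. Compound 3 `O=C(/C=C/c1ccccc1)Nc1cc(Sc2ncn[nH]2)c(O)c2ccccc12` gives > 100000 nM in this assay, likewise a limit. The step that the two limits leave unreadable from compound 2 to compound 3 is therefore not readable. Compound 1 thus stands at the limit of > 100000 nM in this assay, at which 3 of the 3 values shown sit, and no numbered value exists anywhere in the series.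

Compound 4 `Cn1nnnc1Sc1cc(NC(=O)c2ccc(Cl)cc2)c2ccccc2c1O` differs from compound 1 by 1-methyl-1H-tetrazol-5-yl in place of 5-methyl-1,3,4-thiadiazol-2-yl on a sulfur. Among the compounds with values here, no measured step touches the sulfur-bound ring; the only measured step, a step that the two limits leave unreadable from compound 2 to compound 3, concerns the group on the carbonyl carbon and is itself unreadable. The expected step that the limit leaves unreadable from compound 1 to compound 4 therefore has no readable size, and compound 4 is expected most likely to stay at the limit of this assay as well. Compound 4 is estimated at 150000 nM, with a range from 30000 nM to 500000 nM.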

Compound 4, half-maximal inhibitory concentration: > 100000 nM
Compound 4 was reported as a limit; the forecaster's own chance of this, stated with the estimate: 85%; the middle value does not contradict the limit.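

Compound 1 and compound 4 both stand only as limits in this assay, so no size can be read for 1-methyl-1H-tetrazol-5-yl in place of 5-methyl-1,3,4-thiadiazol-2-yl on a sulfur. The compounds shown leave open which change to the shared core, if any, would give a numbered value: the limit of > 100000 nM in this assay, at which 4 of the 4 values shown sit.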